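Amide ring swap: thiophen-3-yl to 1-methyl-1H-pyrazol-5-yl

This account rests on a few compounds, and the source may have more. Where it says the series, first, only, none or still open, it means among the compounds named here.

- compound 1 `CCCCCCCCCCCC[C@@H](O)[C@H]1CC[C@H]([C@H](O)CCCCCCCCCCNC(=O)c2cccs2)O1`: 2190 nM
- compound 2 `CCCCCCCCCCCC[C@@H](O)[C@H]1CC[C@H]([C@H](O)CCCCCCCCCCNC(=O)c2ccoc2)O1`: 26900 nM
- compound 3 `CCCCCCCCCCCC[C@@H](O)[C@H]1CC[C@H]([C@H](O)CCCCCCCCCCNC(=O)c2ccsc2)O1`: 2000 nM

All three values come from a functional assay on MCF7 cells (Homo sapiens) for inhibition, read by colorimetric assay and sulforhodamine B assay, with a stated time of 48 h; on this read-out lower numbers stand for stronger inhibition of growth and higher numbers for weaker inhibition of growth. Compound 3 stands level with compound 1 at the low end of these numbers, and the two thiophene amides agree: a 1.1-fold lower number from compound 1 to compound 3 (0.04 log units; within the scatter). Compound 2 stands apart, and the step of a 13-fold lower number from compound 2 to compound 3 (1.13 log units; beyond the scatter) separates it clearly from compound 3.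

Compound 4 `CCCCCCCCCCCC[C@@H](O)[C@H]1CC[C@H]([C@H](O)CCCCCCCCCCNC(=O)c2ccnn2C)O1` carries 1-methyl-1H-pyrazol-5-yl in place of thiophen-3-yl on a carbonyl carbon.

Two kinds of measured step bear on this change. Moving between the two thiophene rings changed nothing beyond the scatter, but leaving thiophene for furan-3-yl was large: a 12-fold higher number from compound 1 to compound 2 (1.09 log units; beyond the scatter). The only measured ring that is not a thiophene, in compound 2 at 26900 nM, gave the high number, so a rise is expected in this assay. Within the data shown here, no measured compound carries a pyrazole, which leaves the size uncertain, and a step somewhat smaller than the furan step seems the fair expectation. The expected step is a 4.5-fold higher number from compound 3 to compound 4 (0.65 log units; beyond the scatter). For compound 4 the estimated value is 9000 nM, with an expected range from 2200 nM to 35000 nM.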

Compound 4, concentration for 50% growth inhibition: 3240 nM
The estimate for compound 4 lay 2.8-fold (0.44 log units) above the measured number, within the range that was stated.
By their numbers in this assay, from the lowest: compounds 3, 1 and 4 (each within the scatter of the next); then compound 2.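

Working notes on the amide ring: in this assay, 1-methyl-1H-pyrazol-5-yl sits level with both thiophene amides, with a 1.6-fold higher number from compound 3 to compound 4 (0.21 log units; within the scatter) and a 1.5-fold higher number from compound 1 to compound 4 (0.17 log units; within the scatter). A sulfur atom in the ring is therefore not required to hold this level, since a five-membered aromatic ring with 2 hetero atoms, both nitrogen, and 2 hydrogen-bond acceptors on the carbonyl carbon does the same. The pyrazole also stands well apart from the furan, with an 8.3-fold lower number from compound 2 to compound 4 (0.92 log units; beyond the scatter), so leaving thiophene does not in itself raise the number here, and among these four amides only compound 2, the furan-3-yl amide, goes against the level shared by the other three; no accompanying measurement offers an explanation for that split.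

From the compounds shown here alone, it remains open how much the methyl group on the pyrazole contributes, which a pyrazole without that methyl group would test, and whether furan-2-yl repeats the high number of furan-3-yl. A six-membered ring such as phenyl or pyridin-3-yl on the same carbonyl carbon would show whether this position extends beyond five-membered aromatic rings.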